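Adding a Methoxy to Compound 3

This account rests on a few compounds, and the source may have more. Where it says the series, first, only, none or still open, it means among the compounds named here.

In a physicochemical assay for lipophilicity, measured as octanol-water partition (on this read-out higher numbers stand for higher lipophilicity and lower numbers for lower lipophilicity), compound 1 `O=C(NNc1ccnc2cc(Cl)ccc12)c1ccccc1/N=C/c1ccc(Cl)cc1` gives 5.62 and compound 2 `O=C(NNc1ccnc2cc(Cl)ccc12)c1ccccc1/N=C/c1ccc(Cl)c(Cl)c1` gives 6.22. Compound 3 `COc1ccc(/C=N/c2ccccc2C(=O)NNc2ccnc3cc(Cl)ccc23)cc1OC` stands lowest of the three at 4.97. Compound 4 `COc1cc(/C=N/c2ccccc2C(=O)NNc2ccnc3cc(Cl)ccc23)cc(OC)c1OC` differs from compound 3 by methoxy in place of hydrogen on an aromatic carbon, with the methoxy entering ortho to a methoxy group. Among the compounds with values here, no measured step makes exactly this change. The only replacement of hydrogen, by chloro, gave a number 0.60 log units higher from compound 1 to compound 2 (beyond the scatter), a modest step. The two steps that bring in 3,4-dimethoxyphenyl were modest and large, giving a number 0.65 log units lower from compound 1 to compound 3 (beyond the scatter) and a number 1.25 log units lower from compound 2 to compound 3 (beyond the scatter). These point downward and the chloro step upward, yet both downward steps exchange whole groups and do not isolate one added methoxy. The evidence therefore fixes no firm direction, and in this assay a small drift at most is expected, probably none beyond the scatter. The expected change is a number 0.07 log units lower from compound 3 to compound 4 (within the scatter). For compound 4 the estimated value is 4.9, with an expected range from 4.5 to 5.35.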

Compound 4, partition coefficient: 4.94
Compound 4: the middle estimate sits 0.04 log units below what was measured; measured number inside the range.
By their numbers in this assay, from the lowest: compounds 4 and 3 (each within the scatter of the next); then compound 1; then compound 2.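

In this assay the step from hydrogen to methoxy, on the aromatic carbon ortho to a methoxy group and meta to a large group, gives a number 0.03 log units lower from compound 3 to compound 4 (within the scatter) and so isolates one added methoxy, which the earlier exchanges of whole groups could not do. At this position on this core the added methoxy leaves the partition read-out unmoved, unlike the chloro step elsewhere on the shared scaffold, which gives a number 0.60 log units higher from compound 1 to compound 2 (beyond the scatter) and lies beyond the scatter. Nothing on hand offers an explanation for this flat step.

The compounds shown leave open whether an amine, a carboxylic acid or a longer chain such as butoxy at this same carbon would also leave the read-out flat. They also leave open whether methoxy would behave the same way on the 4-chlorophenyl ring of compound 1.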